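The source may report more compounds than this note shows. Statements on the series, on what has been measured and on what is new or still open speak of the compounds shown alone.

Measured in a functional assay on HEL cells (Homo sapiens) for cytotoxicity, read by microscopy; a lower number here means that less compound is tolerated, a higher number that more compound is tolerated:
compound 1 `Cc1cn([C@@H]2O[C@H](CO[Si](C)(C)C(C)(C)C)[C@@]3(OS(=O)(=O)C=C3NCC(N)=O)[C@H]2O[Si](C)(C)C(C)(C)C)c(=O)n(C)c1=O` 16000 nM;
compound 2 `Cc1cn([C@@H]2O[C@H](CO[Si](C)(C)C(C)(C)C)[C@@]3(OS(=O)(=O)C=C3NC(N)=O)[C@H]2O[Si](C)(C)C(C)(C)C)c(=O)n(C)c1=O` 16000 nM;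
compound 3 `Cc1cn([C@@H]2O[C@H](CO[Si](C)(C)C(C)(C)C)[C@@]3(OS(=O)(=O)C=C3NC(=O)NC(=O)c3ccccc3)[C@H]2O[Si](C)(C)C(C)(C)C)c(=O)n(C)c1=O`, whose value >= 80000 nM is a limit of the assay, not a number.

Compound 1 sits level with compound 2 here; the pair shows no change at the digits printed from compound 1 to compound 2 (within the scatter). Compound 4 `CCNC(=O)NC1=CS(=O)(=O)O[C@@]12[C@@H](CO[Si](C)(C)C(C)(C)C)O[C@@H](n1cc(C)c(=O)n(C)c1=O)[C@@H]2O[Si](C)(C)C(C)(C)C` differs from compound 1 by ethylcarbamoyl in place of carbamoylmethyl on an amine nitrogen. Going by the values given here, two measured steps bear on it: an at least 5.0-fold higher number from compound 1 to compound 3 (0.69 log units; beyond the scatter) and an at least 5.0-fold higher number from compound 2 to compound 3 (0.69 log units; beyond the scatter), both reaching only (the limit of >= 80000 nM in this assay, at which 1 of the 3 values shown sits). Ethylcarbamoyl shares with compound 3 a substituent on the amide-type nitrogen, though a smaller one, so a step towards a higher number, of uncertain size, is expected for compound 4, estimated as a 2.0-fold higher number from compound 1 to compound 4 (0.30 log units; within the scatter). The value of compound 4 in this assay is estimated at 32000 nM, within 12000 nM to 80000 nM.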

Compound 4, minimum cytotoxic concentration: >= 3200 nM
Compound 4: no number, only a limit; the forecaster's own chance of this, stated with the estimate: 30%; the middle value is on the limit's open side.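

In this assay compound 4 gives >= 3200 nM, a limit and not a number. Going by these compounds alone, no step to compound 4 from compound 1, compound 2 or compound 3 can be read. Where ethylcarbamoyl stands relative to carbamoylmethyl, carbamoyl and benzoylcarbamoyl on the amine nitrogen stays open.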